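Moving the methoxy group from compound 2 to compound 3

The source may hold more compounds than are shown below. What is called first, only, known or untested is meant among the compounds shown, and "the series" means these compounds.

Measured so far:
compound 1 `CNc1nccc(N2CC[C@H](NC(=O)Nc3cccc(C#N)c3)C2)n1` gives 94.4%
compound 2 `CNc1nccc(N2CC[C@H](NC(=O)Nc3ccc(OC)cc3)C2)n1` gives 80%

In an ADME assay on a cell-free system (plasma, Homo sapiens) for protein binding, compound 2 has the higher unbound fraction of the two and gives 80%. Compound 3 `CNc1nccc(N2CC[C@H](NC(=O)Nc3cccc(OC)c3)C2)n1` has 3-methoxyphenyl in place of 4-methoxyphenyl on an amide-type nitrogen and is not yet measured. For the measured compounds named here, only one measured step bears on this change, a 3.6-fold higher unbound fraction from compound 1 to compound 2 (0.55 log units; beyond the scatter) and it replaced the group itself. Compound 3 keeps the methoxy of compound 2, so a smaller change is expected in this assay with the direction uncertain but leaning toward compound 1. The expected step is a 1.4-fold lower unbound fraction from compound 2 to compound 3 (0.15 log units; within the scatter) and it rests on this single comparison. Compound 3 is estimated at 86% with an expected range of 72% to 93% in this assay.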

Compound 3, plasma protein binding: 96.7%
Compound 3: the middle estimate sits 4.2-fold (0.63 log units) (unbound fraction) above what was measured; the measured number lies above the stated range.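

In this assay, moving the methoxy alone gives a 6.1-fold lower unbound fraction from compound 2 to compound 3 (0.78 log units; beyond the scatter) for 3-methoxyphenyl in place of 4-methoxyphenyl on an amide-type nitrogen, so this change is not a small one. Methoxy in place of cyano on an aromatic carbon gives a 1.7-fold lower unbound fraction from compound 1 to compound 3 (0.23 log units; within the scatter) and stays within the scatter. Across compound 1, compound 2 and compound 3, where the group sits on the phenyl therefore counts for more than which of these two groups it is. Open, as far as these compounds go, is whether an amine, a carboxylic acid or a longer chain in place of the methoxy would show the same dependence on where the group sits. Nothing at hand accounts for the gap between the two methoxy compounds.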